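The compounds below may be only part of what the source reports. "The series", "measured", "known", "first", "only" and "open" are said of these compounds alone.

Compound 1 `CC(C)(C)c1cc(NC(=O)N2CCCN(c3ncc(C(F)(F)F)cc3Cl)CC2)no1` and compound 2 `CC(C)(C)c1cc(NC(=O)N2CCCN(c3ccc(C(F)(F)F)cn3)CC2)no1` share one core and differ at a single spot on the ring that carries the trifluoromethyl group. In a physicochemical assay for solubility, at pH 7.4 (a lower number here means a less soluble compound, a higher number a more soluble compound), compound 1 gives 0.6 ug/mL. In this assay compound 2 gives 0.4 ug/mL. The step between them is a 1.5-fold lower number from compound 1 to compound 2 (0.18 log units; within the scatter), so the two numbers cannot be told apart, and compound 2 stands level with compound 1 rather than apart from it. Compound 3 `CC(C)(C)c1cc(NC(=O)N2CCCN(c3ccc(C#N)cn3)CC2)no1` is not yet measured; it differs from compound 2 by cyano in place of trifluoromethyl on an aromatic carbon. Within the data shown here, no measured step covers this kind of change: the only step seen, a 1.5-fold lower number from compound 1 to compound 2 (0.18 log units; within the scatter), concerns a different group and stayed within the scatter, so it gives no guide to size or direction here. With that in mind a modest rise is expected, a 3.8-fold higher number from compound 2 to compound 3 (0.57 log units; beyond the scatter), carrying wide uncertainty. Compound 3 is estimated to give about 1.5 ug/mL in this assay, most likely between 0.4 ug/mL and 6 ug/mL.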

Compound 3, solubility: 13 ug/mL
The estimate for compound 3 lay 8.7-fold (0.94 log units) below the measured number; measured number outside the range, above it.
By their numbers in this assay, from the lowest: compounds 2 and 1 (each within the scatter of the next); then compound 3.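

In this assay, replacing trifluoromethyl with cyano on this aromatic carbon, para to a large group, gives a 33-fold higher number from compound 2 to compound 3 (1.51 log units; beyond the scatter), a large step and the first one here beyond the scatter. The earlier change at a different spot on the ring gave only a 1.5-fold lower number from compound 1 to compound 2 (0.18 log units; within the scatter), so a single replacement on this ring does not always leave the number within the scatter. The new group has fewer heavy atoms and one hydrogen-bond acceptor where the old group had none, but nothing available shows which difference, if either, lies behind the step.

As far as these compounds go, it remains open whether other groups on this carbon, such as an amine, a carboxylic acid or a methoxy group, would give a step of similar size. Also open, from the compounds shown here alone, is whether the same replacement would give a similar step on compound 1, which carries chloro.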